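A few compounds are considered here, and "the series" means these few. Any claim that something is new, unique, unknown or untested is made for them only; others in the source may bear on it.

The series shares the core of compound 1 `Cc1ccc2nc(N3CCCc4ccc(F)cc4C3)cc(NCC3(N)COC3)c2c1` and varies the chain on the nitrogen on the aromatic ring. In an ADME assay on HEp-2 cells (Homo sapiens) for cytotoxicity, read by CCK-8 assay, with a stated time of 5 days (a higher number here means that more compound is tolerated, a lower number that less compound is tolerated), compound 1 gives only a limit of the assay, > 100000 nM. Compound 2 `Cc1ccc2nc(N3CCCc4ccc(F)cc4C3)cc(NCCN(C)C)c2c1` gives 89000 nM in this assay, and compound 3 `Cc1ccc2nc(N3CCCc4ccc(F)cc4C3)cc(NCCN3CCNCC3)c2c1` gives 40000 nM. Compound 3 thus holds the lowest of the two numbers recorded, with compound 2 nearest to it; the step from compound 2 to compound 3 reads a 2.2-fold lower number from compound 2 to compound 3 (0.35 log units; beyond the scatter). Against compound 1 the steps read an at least 1.1-fold lower number from compound 1 to compound 2 (0.05 log units; that floor lies within the scatter) and an at least 2.5-fold lower number from compound 1 to compound 3 (0.39 log units; beyond the scatter), where the limit of > 100000 nM in this assay, at which 1 of the 3 values shown sits, caps what the first of these can show.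

Compound 4 `Cc1ccc2nc(N3CCCc4ccc(F)cc4C3)cc(NC(=O)CN)c2c1` alters the same position more deeply: (aminomethyl)carbonyl in place of 2-(piperazin-1-yl)ethyl on a nitrogen on an aromatic ring. Among the compounds with values here, no measured step shortens the chain this far or brings in a carbonyl; the three steps at hand all exchange one amine group for another and stay within a narrow band, the largest being the one that arrives at compound 3. With the piperazin-1-yl ring that accompanied the lowest number taken away, a move back toward the level of compound 2, or somewhat past it, is expected for compound 4, read as a 1.8-fold higher number from compound 3 to compound 4 (0.24 log units; within the scatter). The value expected for compound 4 in this assay is 70000 nM, with a range from 35000 nM to 150000 nM.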

Compound 4, half-maximal cytotoxic concentration: > 100000 nM
Compound 4: only a limit was reported; the forecaster's own chance of this, stated with the estimate: 35%; middle value at least 1.4-fold (0.15 log units) away from the limit.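

In this assay compound 4 gives only a limit of the assay, > 100000 nM. Within the data shown here, replacing 2-(piperazin-1-yl)ethyl with (aminomethyl)carbonyl on the nitrogen on an aromatic ring, the first change here that brings in a carbonyl, gives an at least 2.5-fold higher number from compound 3 to compound 4 (0.39 log units; beyond the scatter), while the same group in place of 2-(dimethylamino)ethyl gives an at least 1.1-fold higher number from compound 2 to compound 4 (0.05 log units; that floor lies within the scatter), so only the first of these floors shows a change beyond the scatter. Compound 1 and compound 4 carry quite different groups at this position yet both end at the limit, so the step between them cannot be read and the other two steps give floors rather than sizes, because the upper end of the assay is reached twice: the limit of > 100000 nM in this assay, at which 2 of the 4 values shown sit.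

The change from compound 3 to compound 4 removes the ring, shortens the group and brings in the carbonyl all at once, so these three differences stay unseparated in the compounds shown. Going by these compounds, a plain 2-aminoethyl chain, or a (piperazin-1-yl)acetyl group that keeps the ring alongside the carbonyl, would bear on which of them goes with the change, and how far compound 4 lies past its limit remains open.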